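Amide tail swap: compound 2 to compound 3

The source may hold more compounds than are shown below. What is called first, only, known or untested is meant among the compounds shown, and "the series" means these compounds.

Measured so far:
compound 1 `CCCCCCCCCCC(C)(C)C(=O)Nc1c(C)c(N)c(C)c2c1OC(C)(C)C2` — 59 nM
compound 2 `Cc1cc(C)c(NC(=O)C(C)(C)CCCCCCN2CCCCC2)c2c1CC(C)(C)O2` — > 500 nM

In an assay for inhibition of acyl-CoA:cholesterol acyltransferase (Oryctolagus cuniculus), using microsomes (on this read-out lower numbers stand for stronger inhibition and higher numbers for weaker inhibition), compound 1 gives 59 nM. For compound 2 the read-out is only a limit, > 500 nM, not a number. Compound 2 therefore stands at the limit of > 500 nM in this assay, at which 1 of the 2 values shown sits, with no value inside the measured range. Compound 1 and compound 2 differ in more than one place, so the pair shows only that one is measurable and the other is not.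

Compound 3 `Cc1cc(C)c(NC(=O)C(C)(C)CCCCCCc2ccccc2)c2c1CC(C)(C)O2` is not yet measured. It differs from compound 2 by phenyl in place of piperidin-1-yl on a saturated chain carbon, seven bonds along the chain from a carbonyl carbon. Among the measured compounds shown here, no step between measured compounds that differ in one place is available, so no measured step guides the size. The expected step, an at least 2.5-fold lower number from compound 2 to compound 3 (0.39 log units; beyond the scatter), runs toward stronger inhibition and beyond the scatter, with wide uncertainty since compound 2 is known only as a limit. For compound 3 the estimate in this assay is 200 nM, with a range from 50 nM to 1000 nM.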

Compound 3, half-maximal inhibitory concentration: 81 nM
Compound 3: the middle estimate sits 2.5-fold (0.39 log units) above what was measured; the measured number falls inside the stated range.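

In this assay, phenyl in place of piperidin-1-yl on a saturated chain carbon, seven bonds along the chain from a carbonyl carbon, gives an at least 6.1-fold lower number from compound 2 to compound 3 (0.79 log units; beyond the scatter). Among the compounds shown here, this is the only comparison so far that differs in one place, and it shows that the group at this chain end affects inhibition on the shared core, which compound 1 and compound 2 could not show. The full size of the step cannot be read, because compound 2 has only a limit and not a number: the limit of > 500 nM in this assay, at which 1 of the 3 values shown sits.

On these data alone, it remains open whether a chain ending in a dimethylamino group or a carboxylic acid, or a longer chain ending in phenyl, would match compound 3. Compound 1 and compound 3 differ in more than one place, so the contribution of each difference also remains unresolved.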